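The source may report more compounds than this note shows. Statements on the series, on what has been measured and on what is new or still open speak of the compounds shown alone.

Measured so far in an assay on isolated protein for inhibition of DNA topoisomerase 1 (Homo sapiens), tested at 100 uM; on this read-out lower numbers stand for a weaker effect and higher numbers for a stronger effect at the one concentration tested:
compound 1, `Clc1cccc(-c2cc(-c3ccc(Cl)o3)cc(-c3ccsc3)n2)c1`: 0%
compound 2, `Cc1ccc(-c2cc(-c3ccc(Cl)o3)cc(-c3ccsc3)n2)cc1`: 2.6%
compound 3, `Clc1ccc(-c2cc(-c3ccsc3)nc(-c3ccco3)c2)o1`: 8.2%

Compound 3 holds the highest of the three numbers, but its margin over the other two stays within the scatter: a number 5.6 percentage points higher from compound 2 to compound 3 (within the scatter) and a number 8.2 percentage points higher from compound 1 to compound 3 (within the scatter). All three share one core and differ only in the group on the aromatic carbon next to the ring nitrogen. Compound 4, `Cc1ccccc1-c1cc(-c2ccc(Cl)o2)cc(-c2ccsc2)n1`, carries a further variant at that place: 2-methylphenyl in place of furan-2-yl on an aromatic carbon.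

Within the data shown here, two measured steps bear on this change, both running in the opposite direction, from a six-membered carbon ring to furan-2-yl: a number 8.2 percentage points higher from compound 1 to compound 3 (within the scatter) and a number 5.6 percentage points higher from compound 2 to compound 3 (within the scatter). A third step, a number 2.6 percentage points higher from compound 1 to compound 2 (within the scatter), compares two six-membered carbon rings with each other. None of the three reached beyond the scatter, and the two carbon-ring compounds, compound 1 and compound 2, both sit at the low end of the set. Putting a six-membered carbon ring back in place of furan-2-yl is therefore expected to move the read-out slightly downward, by a number 5.2 percentage points lower from compound 3 to compound 4 (within the scatter), a step that itself stays within the scatter. For compound 4 the expected value in this assay is 3%, with a range from 0% to 12%.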

Compound 4, a percentage reported as inhibition, at one concentration (the size of the read-out at that concentration, not a potency): 6.7%
Beside the measured number, compound 4's estimate is 3.7 percentage points below it; measured number inside the range.
By their numbers in this assay, from the lowest: compounds 1, 2, 4 and 3 (each within the scatter of the next).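

Working notes on the position next to the ring nitrogen: in this assay, the 2-methylphenyl group adds a third six-membered carbon ring at this place, and replacing furan-2-yl with it gives no separable change (a number 1.5 percentage points lower from compound 3 to compound 4 (within the scatter)). The two comparisons with the other carbon-ring compounds also stay inside the scatter (a number 4.1 percentage points higher from compound 2 to compound 4 (within the scatter); a number 6.7 percentage points higher from compound 1 to compound 4 (within the scatter)), so moving from 4-methylphenyl to 2-methylphenyl, or from 3-chlorophenyl to 2-methylphenyl, does not resolve into an effect, and the set gives no basis for separating carbon rings from furan-2-yl at this place. No measurement on these compounds offers an explanation for these small steps.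

The compounds shown leave open whether any group at this place can lift the read-out clear of the scatter, for example an aminomethyl group, a morpholine or a carboxylic acid. They also leave open what happens when the 5-chlorofuran-2-yl or thiophen-3-yl group is replaced, as both stay the same throughout these compounds.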